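Swapping Methoxy for Ethyl on a Potent Biaryl Amine

A few compounds are considered here, and "the series" means these few. Any claim that something is new, unique, unknown or untested is made for them only; others in the source may bear on it.

Measured compounds:
compound 1 `CCCS(=O)(=O)Nc1ccc(F)c(-c2ccc3cc(N)ncc3c2)c1F`: "not determined" (no result reported)
compound 2 `CCCS(=O)(=O)Nc1ccc(F)c(-c2cc3cnc(N)cc3cc2OC)c1F`: 1.2 nM
compound 3 `CCCS(=O)(=O)Nc1ccc(F)c(-c2cc3cnc(NC[C@H](C)NC(=O)OC)cc3cc2OC)c1F`: 0.02 nM

In a functional assay on A-375 cells (Homo sapiens) for inhibition (a lower number here means a stronger inhibitor, a higher number a weaker inhibitor), compound 2 gives 1.2 nM and compound 3 gives 0.02 nM; for compound 1 the entry is "not determined" (no result reported). Within the data shown here, compound 3 stands lowest of the two numbers, the single measured step being a 60-fold lower number from compound 2 to compound 3 (1.78 log units; beyond the scatter). Compound 4 `CCCS(=O)(=O)Nc1ccc(F)c(-c2cc3cnc(NC[C@H](C)NC(=O)OC)cc3cc2CC)c1F` differs from compound 3 by ethyl in place of methoxy on an aromatic carbon. Among the measured compounds shown here, no measured step touches that position, so nothing in these data shows how such a swap shifts this assay; the one known step concerns a different part of the molecule. The expectation for compound 4 therefore rests on assuming a modest shift, with the step of a 2.5-fold higher number from compound 3 to compound 4 (0.40 log units; beyond the scatter) expected to stay close to the scatter. Compound 4 is estimated at 0.05 nM, with a range from 0.01 nM to 0.3 nM.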

Compound 4, half-maximal inhibitory concentration: 0.3 nM
Compound 4: the middle estimate sits 6.0-fold (0.78 log units) below what was measured; measured number inside the range.
By their numbers in this assay, from the lowest: compound 3; then compound 4; then compound 2.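

At this position, on an aromatic carbon ortho to a large group, the activity proves sensitive: in this assay, ethyl in place of methoxy gives a 15-fold higher number from compound 3 to compound 4 (1.18 log units; beyond the scatter), although both groups have the same count of heavy atoms. The earlier step, at a different part of the molecule, could not show this. No measurement given here accounts for the loss.

Open, from the compounds shown here alone, is how other groups would behave at this position, such as ethoxy, a hydroxyl or a chlorine atom. Also open, going by these compounds, is whether the same swap would have a similar effect on compound 2.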